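This account rests on a few compounds, and the source may have more. Where it says the series, first, only, none or still open, it means among the compounds named here.

For the measured compounds named here, compound 1 `CSc1ccc(-c2nc3sc(S(N)(=O)=O)nn3c2-c2ccccc2)cc1` is one of three compounds so far measured in an ADME assay on Vero cells (Chlorocebus sabaeus) for cytotoxicity, read by MTT assay, with a stated time of 72 h; a higher number here means a weaker inhibitor, a lower number a stronger inhibitor. Compound 1 gives 192000 nM, the second highest of the three numbers. Compound 2 `COc1ccc(-c2c(-c3ccc(SC)cc3)nc3sc(S(N)(=O)=O)nn23)cc1` gives 213000 nM, the nearest number to it. Compound 3 `COc1ccc(-c2c(-c3ccc(SC)cc3)nc3sc(-c4ccc(F)cc4)nn23)cc1` gives 116000 nM, the furthest from it. Both gaps lie within the scatter, as does the step of a 1.1-fold higher number from compound 1 to compound 2 (0.05 log units; within the scatter), so no ordering among the three can be read from these numbers.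

Compound 4 `COc1ccc(-c2nn3c(-c4ccccc4)c(-c4ccc(SC)cc4)nc3s2)cc1` has not yet been measured. It differs from compound 1 in a single place: 4-methoxyphenyl in place of sulfamoyl on an aromatic carbon. Going by the values given here, one measured step bears on this change, a 1.8-fold lower number from compound 2 to compound 3 (0.26 log units; within the scatter), where 4-fluorophenyl took the place of sulfamoyl at the same position of the core; that step stayed within the scatter. An aromatic ring entering for sulfamoyl has thus given no clear shift, and the same is expected here: a step of a 1.4-fold lower number from compound 1 to compound 4 (0.14 log units; within the scatter) that is expected to remain within the scatter. Compound 4 is therefore estimated at 140000 nM, with a range from 60000 nM to 320000 nM.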

Compound 4, half-maximal inhibitory concentration: 135000 nM
Beside the measured number, compound 4's estimate is 1.0-fold (0.02 log units) above it; the measured number falls inside the stated range.
By their numbers in this assay, from the lowest: compounds 3, 4, 1 and 2 (each within the scatter of the next).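

In this assay, putting 4-methoxyphenyl in place of sulfamoyl gives a 1.4-fold lower number from compound 1 to compound 4 (0.15 log units; within the scatter), so a second aromatic ring at this place again produces no clear shift. The earlier step at this position used 4-fluorophenyl on the core of compound 2, whereas this one uses a different incoming ring on the core of compound 1, so the lack of a clear shift now holds for two pairs, even though the hydrogen-bond donor of sulfamoyl is lost in both. No measurement shown here explains this lack of a shift.

On these data alone, at this position the compounds carry only sulfamoyl or an aromatic ring, so the effect of an amine or a carboxylic acid there remains open. Every step shown lies within the scatter, so it is also open whether any change at this place would clearly move the number.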